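The source may report more compounds than this note shows. Statements on the series, on what has been measured and on what is new or still open speak of the compounds shown alone.

Measured so far:
Compound 1 `CCOC(=O)CCCCCOc1cccc(CN(C(=O)c2ccc(-c3cccc(OC(C)C)c3)cc2)C(C)C)c1` gives > 26000 nM in an ADME assay on HEK293 cells (Homo sapiens) for cytotoxicity, read by CellTiter-Glo and resazurin assay, with a stated time of 72 h; on this read-out higher numbers stand for an effect only at larger amounts of compound and lower numbers for an effect already at smaller amounts.
Compound 2 `CCOC(=O)CCCCCOc1cccc(CN(C(=O)c2ccc(-c3cccc(Oc4ccccc4)c3)cc2)C(C)C)c1` gives > 19600 nM.
Compound 3 `CCOC(=O)CCCCCOc1cccc(CN(C(=O)c2ccc(-c3cccc(OCc4ccccc4)c3)cc2)C(C)C)c1` gives > 26000 nM.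

The three compounds share one core and differ only in the group on an oxygen of the outer aromatic ring. For compound 1 the value is a limit of this assay, not a number. For compound 2 the value is likewise a limit. For compound 3 the value is also a limit. What is known thus comes down to the limit of > 26000 nM in this assay, at which 2 of the 3 values shown sit, and (the limit of > 19600 nM in this assay, at which 1 of the 3 values shown sits). The step that the two limits leave unreadable from compound 1 to compound 2 cannot be sized, and the same holds for a step that the two limits leave unreadable from compound 1 to compound 3 and for a step that the two limits leave unreadable from compound 2 to compound 3. So compound 1 stands at a limit, with no measured neighbour that reaches a readable number.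

Compound 4 `CCOC(=O)CCCCCOc1cccc(CN(C(=O)c2ccc(-c3cc(F)cc(OC)c3)cc2)C(C)C)c1` is not yet measured. It differs from compound 1 as follows: 3-fluoro-5-methoxyphenyl in place of 3-isopropoxyphenyl on an aromatic carbon. Among the measured compounds shown here, none of the measured steps bears on this change with a readable size, so no step beyond the scatter in either direction can be drawn from them. Compound 4 is therefore expected to give 26000 nM, within 10000 nM to 60000 nM, most likely again as a limit. The expected step from this is a number no higher from compound 1 to compound 4 (the limit leaves the size open).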

Compound 4, half-maximal effective concentration: > 26000 nM
Compound 4 was reported as a limit; the forecaster's own chance of this, stated with the estimate: 85%; the middle value sits exactly at the limit.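

Among the compounds shown here, compound 1 and compound 4 both stand at a limit of this assay and not at a number, so no step between them can be read: the limit of > 26000 nM in this assay, at which 3 of the 4 values shown sit. The compounds shown leave open at what concentration any of them reaches its half-maximal effect on these cells, and whether changing the outer ring shifts that concentration at all.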